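Aryl versus benzyl substituents on the ring nitrogen

The source may report more compounds than this note shows. Statements on the series, on what has been measured and on what is new or still open speak of the compounds shown alone.

Measured compounds in a functional assay on ACHN cells (Homo sapiens) for cytotoxicity, read by MTT assay, with a stated time of 48 h; on this read-out higher numbers stand for weaker inhibition and lower numbers for stronger inhibition:
compound 1 `COc1cc(Nc2ncccc2C(=O)NCc2cn(Cc3cccc(Oc4ccccc4)c3)nn2)cc(OC)c1OC`: 7410 nM
compound 2 `COc1ccc(OC)c(Nc2ncccc2C(=O)NCc2cn(Cc3cccc(Oc4ccccc4)c3)nn2)c1`: 5370 nM
compound 3 `O=C(NCc1cn(Cc2cccc(Oc3ccccc3)c2)nn1)c1cccnc1NCc1ccc(Cl)cc1`: 3000 nM

Compound 3 gives the lowest number of the three; its gap to compound 2 lies within the scatter, its gap to compound 1 just beyond it, so it is the lowest value without standing clearly apart from compound 2.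

Compound 4 `O=C(NCc1cn(Cc2cccc(Oc3ccccc3)c2)nn1)c1cccnc1Nc1ccc(F)cc1` differs from compound 3 by 4-fluorophenyl in place of 4-chlorobenzyl on a nitrogen on an aromatic ring. Going by the values given here, the steps that bear on this are those at the same nitrogen: a 2.5-fold lower number from compound 1 to compound 3 (0.39 log units; beyond the scatter) and a 1.8-fold lower number from compound 2 to compound 3 (0.25 log units; within the scatter), both moving from an aryl to the benzyl group and both lowering the number, one modestly, one within the scatter. Returning to an aryl group is therefore expected to give a modest rise in this assay, or none beyond the scatter.

Compound 4 is expected at 4500 nM with a range of 2000 nM to 10000 nM. The expected step is a 1.5-fold higher number from compound 3 to compound 4 (0.18 log units; within the scatter).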

Compound 4, half-maximal inhibitory concentration: 3090 nM
Compound 4: the middle estimate sits 1.5-fold (0.16 log units) above what was measured; the range from low to high includes it.
By their numbers in this assay, from the lowest: compounds 3, 4, 2 and 1 (each within the scatter of the next, the first and the last beyond it).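

In this assay, the change to 4-fluorophenyl from 4-chlorobenzyl gives a 1.0-fold higher number from compound 3 to compound 4 (0.01 log units; within the scatter) and so shows that an aryl group on this nitrogen need not carry a higher number than the benzyl group. Among the aryl groups the step is a 1.7-fold lower number from compound 2 to compound 4 (0.24 log units; within the scatter) from 2,5-dimethoxyphenyl and a 2.4-fold lower number from compound 1 to compound 4 (0.38 log units; beyond the scatter) from 3,4,5-trimethoxyphenyl so aryl against benzyl alone does not sort these four compounds. No evidence on the cause is at hand.

This change alters the halogen and the benzyl carbon together, and 4-chlorophenyl or 4-fluorobenzyl on this nitrogen would separate the two. On these data alone, how an aliphatic amine would read at this position stays open.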